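The source may report more compounds than this note shows. Statements on the series, on what has been measured and on what is new or still open speak of the compounds shown alone.

Working notes on the series in a functional assay on SEM cells (Homo sapiens) for cytotoxicity, with a stated time of 72 h; a lower number here means that less compound is needed, a higher number that more compound is needed for the effect. Compound 1 `C=C[C@@](C)(/C=C/c1ccc(O)c(/C=C/C(=O)c2ccccc2)c1)CCC=C(C)C` gives 8000 nM. Compound 2 `C=C[C@@](C)(/C=C/c1ccc(O)c(/C=C/C(N)=O)c1)CCC=C(C)C` reads > 36600 nM, which is a limit. Compound 3 `C=C[C@@](C)(/C=C/c1ccc(O)c(/C=C/c2ccc(Cl)cc2)c1)CCC=C(C)C` reads > 36600 nM, also a limit, so it has no number of its own.

Compound 4 `C=C[C@@](C)(/C=C/c1ccc(O)c(/C=C/C=C/c2ccccc2)c1)CCC=C(C)C` differs from compound 3 by one change: 2-phenylethenyl in place of 4-chlorophenyl on a double-bonded chain carbon bound to a double-bonded chain carbon. Like compound 3, it lacks the benzoyl group of compound 1. The closest measured step is an at least 4.5-fold higher number from compound 1 to compound 3 (0.66 log units; beyond the scatter). The change at the carbonyl gave an at least 4.5-fold higher number from compound 1 to compound 2 (0.66 log units; beyond the scatter), while a step that the two limits leave unreadable from compound 2 to compound 3 adds nothing.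

With compound 3 as the reference, no step beyond the scatter is expected in this assay. The expected step is an at least 1.2-fold lower number from compound 3 to compound 4 (0.08 log units; that floor lies within the scatter). For compound 4 the estimated value is 30000 nM, with an expected range of 11000 nM to 70000 nM.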

Compound 4, half-maximal effective concentration: > 15000 nM
Compound 4: a limit, no number; the forecaster's own chance of this, stated with the estimate: 60%; the middle value lies beyond the limit too.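

In this assay compound 4 also reads as a limit, so 2-phenylethenyl at this place, with its double bond outside aromatic rings, yields no number of its own. Going by these compounds alone, the one readable step is an at least 1.8-fold higher number from compound 1 to compound 4 (0.27 log units; that floor lies within the scatter); taken alone, this floor does not show that replacing benzoyl with 2-phenylethenyl moves the value beyond the scatter. The steps among compound 2, compound 3 and compound 4 cannot be read.

Open, on these data alone, is whether a carboxylic acid or an amine on this double-bonded chain carbon would give a measurable value in this assay.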